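The source may hold more compounds than are shown below. What is called first, only, known or untested is meant among the compounds shown, and "the series" means these compounds.

Going by the values given here, compound 1, `CCCCC[Se]c1nc(N)c2ccccc2n1`, is the one compound among the three measured that gives a number in a functional assay on MCF7 cells (Homo sapiens) for cytotoxicity, read by MTT assay, with a stated time of 72 h; a lower number here means that less compound is tolerated, a higher number that more compound is tolerated: compound 1 gives 90400 nM. Compound 2, `C[Se]c1nc(N)c2ccccc2n1`, reaches only a limit of this assay, > 100000 nM. Compound 3, `COc1ccc(CNc2nc(SC)nc3ccccc23)cc1`, likewise reaches only a limit, > 100000 nM. Among the compounds with values here, compound 1 therefore stands as the sole numbered value, while the other two values rest at the limit of > 100000 nM in this assay, at which 2 of the 3 values shown sit. Within the data shown here, the single step measured between two compounds that differ in one place is an at least 1.1-fold higher number from compound 1 to compound 2 (0.04 log units; that floor lies within the scatter), whose floor lies within the scatter. Compound 4, `CCCCC[Se]c1nc(NCc2ccccc2)c2ccccc2n1`, differs from compound 1 by benzyl in place of hydrogen on a nitrogen on an aromatic ring. Among the measured compounds shown here, no measured step touches that nitrogen: the step from compound 1 to compound 2 changes the chain on the selenium, not the nitrogen. For the measured compounds named here, compound 3 is the only other compound carrying a group other than hydrogen on that nitrogen, and it shows only a limit. Going by the values given here, with no measured step bearing on this change, no step beyond the scatter is expected in this assay in either direction, and a limit rather than a number is a real possibility. The step from compound 1 to compound 4 is expected to be a 1.1-fold higher number from compound 1 to compound 4 (0.02 log units; within the scatter). Compound 4 is estimated at 95000 nM, within 30000 nM to 300000 nM.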

Compound 4, concentration lethal to 50% of the cells: 99400 nM
Compound 4: the middle estimate sits 1.0-fold (0.02 log units) below what was measured, and the stated range covers the measured number.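

In this assay, going by these compounds alone, the nitrogen that no earlier step touched now has a measured step of its own: a 1.1-fold higher number from compound 1 to compound 4 (0.04 log units; within the scatter). The hydrogen on this nitrogen of the shared core can therefore give way to benzyl, with its one six-membered aromatic ring of carbon only, without a change that can be told from the scatter, at least while the chain on the selenium stays that of compound 1. Compound 4 joins compound 1 as a second compound with a number, while the other values shown remain limits: the limit of > 100000 nM in this assay, at which 2 of the 4 values shown sit.

The compounds shown leave open whether a smaller group on this nitrogen, such as methyl, or a benzyl ring carrying a carboxylic acid or an amine, would give a step beyond the scatter in this assay. They also leave open whether benzyl on this nitrogen would give the same result in combination with the shorter chain on the selenium of compound 2, or with a longer chain there.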